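A few compounds are considered here, and "the series" means these few. Any claim that something is new, unique, unknown or untested is made for them only; others in the source may bear on it.

In a functional assay on A549 cells (Homo sapiens) for cytotoxicity, read by MTT assay, with a stated time of 48 h (on this read-out higher numbers stand for weaker inhibition and lower numbers for stronger inhibition), compound 1, whose structure is `Cn1cnc(C(=O)NNC(=O)COc2ccc(C(=O)c3ccccc3)cc2)c1`, gives 30600 nM. Compound 3, with structure `O=C(COc1ccc(C(=O)c2ccccc2)cc1)NNC(=O)c1ccc(=O)oc1`, shares the core of compound 1 but carries a different ring on the carbonyl carbon whose other neighbour is an amide-type nitrogen; compound 3 gives 98800 nM in this assay. The change that turns compound 1 into compound 3 is a group of 7 heavy atoms (5 carbon, 2 oxygen; one six-membered aromatic ring with 1 hetero atom) in place of a group of 6 heavy atoms (4 carbon, 2 nitrogen; one five-membered aromatic ring with 2 hetero atoms), on a carbonyl carbon and it makes a 3.2-fold higher number from compound 1 to compound 3 (0.51 log units; beyond the scatter), a step that lies beyond the usual scatter of this kind of measurement.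

Compound 2, whose structure is `Cn1cnc(C(=O)NNC(=O)COc2c(F)cc(C(=O)c3ccc(Cl)cc3)cc2Cl)c1`, gives 49100 nM in this assay. How the core of compound 2 differs from that of compound 1 is not broken down here, since the two differ in more than one place. The values of compound 2 and compound 1 lie within the scatter of each other, as do the values of compound 2 and compound 3.

Compound 4, with structure `O=C(COc1c(F)cc(C(=O)c2ccc(Cl)cc2)cc1Cl)NNC(=O)c1ccc(=O)oc1`, is not yet measured. It stands to compound 2 as compound 3 stands to compound 1: the change is a group of 7 heavy atoms (5 carbon, 2 oxygen; one six-membered aromatic ring with 1 hetero atom) in place of a group of 6 heavy atoms (4 carbon, 2 nitrogen; one five-membered aromatic ring with 2 hetero atoms), on a carbonyl carbon, and the place is the same word for word, so this is the same change. With one shown example, the expectation rests on that example alone, and the step from compound 2 to compound 4 is expected to be a 3.1-fold higher number from compound 2 to compound 4 (0.49 log units; beyond the scatter) because compound 1 to compound 3 gave a 3.2-fold higher number from compound 1 to compound 3 (0.51 log units; beyond the scatter). On that basis compound 4 is expected to give about 150000 nM in this assay, with the likely range running from 70000 nM to 320000 nM.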

Compound 4, half-maximal inhibitory concentration: 88800 nM
The estimate for compound 4 lay 1.7-fold (0.23 log units) above the measured number; low and high end bracket the measured number.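

On the core of compound 2, putting the six-membered ring with one hetero atom in place of the 1-methyl-1H-imidazol-4-yl group gives, in this assay, a 1.8-fold higher number from compound 2 to compound 4 (0.26 log units; within the scatter). Set beside the step seen on the core of compound 1, this new step does not differ from it by more than repeated measurement would allow: the same change on two cores in this assay, a 3.2-fold higher number (0.51 log units; beyond the scatter) from compound 1 to compound 3 and a 1.8-fold higher number (0.26 log units; within the scatter) from compound 2 to compound 4, 1.8-fold (0.25 log units) apart, within the scatter of two such steps

The two cores therefore give no sign that the change behaves differently from one to the other, yet only the first step lies beyond the scatter, and two pairs in a single assay neither fix a size for the change nor show that it would hold on any further core.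

The compounds shown carry only these two rings on the carbonyl carbon, so they leave open how an amine, a carboxylic acid or a plain phenyl ring in that place would read in this assay. They also leave open whether the same change would behave alike on a core bearing a methoxy group or a longer chain.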